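The source may report more compounds than this note shows. Statements on the series, on what has been measured and on what is new or still open speak of the compounds shown alone.

Working notes on the series at a functional assay on HEK293 cells for agonist activity at Free fatty acid receptor 1 (Homo sapiens), read by fluorescence and calcium flux, with a stated time of 10 min; a higher number here means a larger maximal response, a lower number a smaller maximal response.

Compound 1 `CC#CC(CC(=O)O)c1ccc(OCC2COc3ccc(Cl)cc3O2)cc1` is the parent of the set. In this assay, within the data shown here, compound 1 gives 104%, the highest of the two numbers measured so far. Compound 2 `Cn1cncc1C(CC(=O)O)c1ccc(OCC2COc3ccc(Cl)cc3O2)cc1`, which carries 1-methyl-1H-imidazol-5-yl in place of prop-1-yn-1-yl on the saturated chain carbon, gives 62% in this assay; the step is a number 42 percentage points lower from compound 1 to compound 2 (beyond the scatter).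

Compound 3 `CC#C[C@@H](CC(=O)O)c1ccc(OC[C@H]2COc3ccc(Cl)cc3O2)cc1` is the next compound to be measured. Its difference from compound 1 is the two compounds have the same atoms and bonds; at least one stereo element is drawn with a configuration in one of them and without one in the other: 2 of 2 stereo elements differ; a stereocentre at a saturated chain carbon is drawn without a configuration in compound 1 and S in compound 3; a stereocentre at a saturated ring carbon is drawn without a configuration in compound 1 and S in compound 3. No group leaves and none enters; only the drawing of the two stereocentres changes.

Among the measured compounds shown here, the one measured step, from compound 1 to compound 2, concerns a change of group on the saturated chain carbon and not a change of drawn configuration, so it does not bear directly on the step to compound 3. For the measured compounds named here, no measured pair in the set separates a compound drawn without configuration from its single stereoisomer. With the same atoms and bonds present, the expected step of a number 4 percentage points lower from compound 1 to compound 3 (within the scatter) is none beyond the scatter. For compound 3 the estimate in this assay is 100%, with a range from 85% to 115%.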

Compound 3, largest response reached (Emax), in percent of the reference or control that the assay uses: 86%
Compound 3: middle estimate off by 14 percentage points, on the high side; the measured number falls inside the stated range.
By their numbers in this assay, from the lowest: compound 2; then compound 3; then compound 1.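

In this assay, among these compounds, the series now has a first reading on drawn configuration rather than on a change of group: with no group leaving or entering, the step is a number 18 percentage points lower from compound 1 to compound 3 (beyond the scatter). Among the compounds shown here, the maximal response therefore shifts beyond the scatter even when the atoms and bonds stay the same, so the earlier group change is no longer the only kind of change at the saturated chain carbon with a readable step. The one difference available to account for the step is the drawing of the two stereocentres: the fact that one of compounds 1 and 3 is drawn with a defined configuration and the other without, at the place where they differ

Going by these compounds, the saturated chain carbon and the saturated ring carbon change together here, so the share of each in the step stays open, as does the response of any single stereoisomer with the opposite configuration at either centre. On these data alone, it also remains open whether cyclopropyl or but-1-yn-1-yl on the saturated chain carbon, in place of prop-1-yn-1-yl and with the configuration drawn in compound 3, would hold the maximal response or lower it.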